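Pyridyl to phenyl on the piperazine: compound 4 expected

The compounds below may be only part of what the source reports. "The series", "measured", "known", "first", "only" and "open" are said of these compounds alone.

Measured compounds:
compound 1, `CN(Cc1cccnc1)C(=S)SCc1ccc(C(=O)Nc2ccccc2N)cc1`, 68.7%
compound 2, `Nc1ccccc1NC(=O)c1ccc(CSC(=S)N2CCCc3ccccc32)cc1`, 35.7%
compound 3, `Nc1ccccc1NC(=O)c1ccc(CSC(=S)N2CCN(c3cccnc3)CC2)cc1`, 72.5%

In a functional assay on HeLa cells (Homo sapiens) for antiproliferative activity, read by CCK-8 assay, with a stated time of 72 h, tested at 8 uM (a lower number here means a weaker effect, a higher number a stronger effect of the compound at the concentration tested), compound 3 gives the highest of the three numbers, although compound 1 lies within the scatter of it; only compound 2 sits clearly lower. Going by the values given here, the single measured step, a number 33 percentage points lower from compound 1 to compound 2 (beyond the scatter), concerns a different position, the thiocarbonyl carbon, and does not touch the ring nitrogen that changes here. Compound 4, `Nc1ccccc1NC(=O)c1ccc(CSC(=S)N2CCN(c3ccccc3)CC2)cc1`, differs from compound 3 by phenyl in place of pyridin-3-yl on an amine nitrogen in a ring. Among the compounds with values here, no measured pair shows the effect of this exchange, so the expectation rests on compound 3 alone and on the observation that compound 1 and compound 3, which carry the pyridin-3-yl group in different settings, give values within the scatter of each other. Compound 4 is therefore expected to give 68% in this assay, within a range of 50% to 85%, which means an expected step of a number 4.5 percentage points lower from compound 3 to compound 4 (within the scatter), not beyond the scatter in either direction.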

Compound 4, a percentage reported as inhibition, at one concentration (the size of the read-out at that concentration, not a potency): 73.1%
The estimate for compound 4 lay 5.1 percentage points below the measured number; the range from low to high includes it.
By their numbers in this assay, from the lowest: compound 2; then compounds 1, 3 and 4 (each within the scatter of the next).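

Going by these compounds alone, for the first time, a pair of compounds isolates the group on the amine nitrogen in a ring: in this assay, phenyl in place of pyridin-3-yl gives a number 0.6 percentage points higher from compound 3 to compound 4 (within the scatter). At this single concentration, therefore, the read-out does not depend on the ring nitrogen of pyridin-3-yl, and the hydrogen-bond acceptor counted for that group can be lost without a step beyond the scatter. Nothing among the data shown explains why the two groups read alike.

On these data alone, it remains open whether a saturated ring such as cyclohexyl, a benzyl group, or a phenyl carrying an amine or a carboxylic acid would hold the read-out at this position. A reading at one concentration also leaves open whether compound 3 and compound 4 would differ in potency.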